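The source may hold more compounds than are shown below. What is called first, only, known or untested is meant among the compounds shown, and "the series" means these compounds.

Measured in an assay on isolated protein for binding affinity to corticotropin-releasing factor receptor 1 (Homo sapiens); on this read-out higher numbers stand for weaker inhibition and lower numbers for stronger inhibition:

Compound 1 `CCN(CC)c1nc(C)nc(N(CC)c2ccc(C(C)=O)cc2Br)n1`: 17 nM
Compound 2 `CCCN(CC1CC1)c1nc(C)nc(N(CC)c2ccc(N(C)C)cc2C(F)(F)F)n1`: 5 nM
Compound 3 `CCN(c1nc(C)cc(N2CCCCC2)n1)c1ccc(C(C)C)cc1Br`: 29 nM

Compound 3 carries the highest number of the three, but its value lies within the scatter of that of compound 1, so the two cannot be told apart; only compound 2 stands beyond the scatter, with a clearly lower number. Compound 4 `CCCN(CC1CC1)c1cc(C)nc(N(CC)c2ccc(C(C)C)cc2Br)n1` keeps the shared core of compound 3 and differs from it in one place: (cyclopropylmethyl)(propyl)amino in place of piperidin-1-yl on an aromatic carbon. Among the measured compounds shown here, no measured pair shows this very change, so the size of the step is open. Still, the entering group is the same one that compound 2 carries on its own, different core, and in this assay compound 2 gives a number well below that of compound 3. A moderate drop is therefore expected, although the change of core in compound 2 weakens the comparison. The expected step of a 2.9-fold lower number from compound 3 to compound 4 (0.46 log units; beyond the scatter) should exceed the scatter. Compound 4 is expected to give 10 nM, within a range from 3 nM to 35 nM.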

Compound 4, inhibition constant: 9 nM
Estimate against measurement, compound 4: 1.1-fold (0.05 log units) above; the range from low to high includes it.
By their numbers in this assay, from the lowest: compounds 2, 4, 1 and 3 (each within the scatter of the next, the first and the last beyond it).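

In this assay, the exchange of piperidin-1-yl for (cyclopropylmethyl)(propyl)amino on this aromatic carbon, next to the ring nitrogen, gives a 3.2-fold lower number from compound 3 to compound 4 (0.51 log units; beyond the scatter), a modest step beyond the scatter. This is the first pair shown that differs in one place, and it gives the first direct reading at this position: the ring can be given up for the larger group, with 8 heavy atoms in place of 6, without any loss on this read-out. No measurement shown here bears on what lies behind this step.

From the compounds shown here alone, it remains open how much of the step belongs to the cyclopropylmethyl part and how much to the propyl part, and whether a dipropylamino or a morpholin-4-yl group on this carbon would match it. Also open, going by these compounds, is whether the same exchange would give a step of similar size on the core of compound 1.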